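Swapping Selenium for Sulfur in Two Core Series

The source may report more compounds than this note shows. Statements on the series, on what has been measured and on what is new or still open speak of the compounds shown alone.

Measured compounds:
compound 1, `CS/C(=N\C(=O)c1ccno1)NC(=O)c1ccno1`: > 100000 nM
compound 2, `C[Se]/C(=N\C(=O)c1ccno1)NC(=O)c1ccno1`: 0.79 nM
compound 3, `C[Se]/C(=N\C(=O)c1cnc2ccccc2c1)NC(=O)c1cnc2ccccc2c1`: 200 nM

In a functional assay on HT-29 cells (Homo sapiens) for cytotoxicity, read by MTT assay, with a stated time of 72 h (a lower number here means a stronger inhibitor of growth, a higher number a weaker inhibitor of growth), compound 2 gives 0.79 nM, and compound 3 gives 200 nM. For compound 1 the assay returns only a limit, > 100000 nM. The change from compound 2 to compound 1 is a group of 2 heavy atoms (1 carbon, 1 sulfur; no ring) in place of a group of 2 heavy atoms (1 carbon, 1 selenium; no ring), on a carbon with a double bond to nitrogen, and it made a step of an at least 120000-fold higher number from compound 2 to compound 1 (5.10 log units; beyond the scatter), with the value of compound 1 sitting at the limit of > 100000 nM in this assay, at which 1 of the 3 values shown sits. Compound 3 differs from compound 2 in its core; the difference between the two cores is not broken down here. Compound 4 `CS/C(=N\C(=O)c1cnc2ccccc2c1)NC(=O)c1cnc2ccccc2c1`, not yet measured, stands to compound 3 as compound 1 stands to compound 2: the change is a group of 2 heavy atoms (1 carbon, 1 sulfur; no ring) in place of a group of 2 heavy atoms (1 carbon, 1 selenium; no ring), on a carbon with a double bond to nitrogen, the same kind of change at the same kind of place. Within the data shown here, the expectation for compound 4 rests only on the one measured instance of this change, the step of an at least 120000-fold higher number from compound 2 to compound 1 (5.10 log units; beyond the scatter). The expected step is a 500-fold higher number from compound 3 to compound 4 (2.70 log units; beyond the scatter), large and likely beyond what this assay resolves. Compound 4 is therefore expected to give about 100000 nM, within a range from 20000 nM to 300000 nM.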

Compound 4, concentration for 50% growth inhibition: > 100000 nM
Compound 4: a limit, no number; the forecaster's own chance of this, stated with the estimate: 70%; the middle value lies on the limit itself.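

In this assay compound 4 gives > 100000 nM, which is a limit and not a number. Methylsulfanyl in place of the carbon-and-selenium group, on a carbon with a double bond to nitrogen, again brings a large loss of growth inhibition on the second core, with an at least 500-fold higher number from compound 3 to compound 4 (2.69 log units; beyond the scatter), so the direction of the change carried over from one core to the other in these two pairs. The two steps show only that direction and not a shared size, since each is bounded by the assay's limit and neither gives an exact measure: the same change on two cores in this assay, an at least 120000-fold higher number (5.10 log units; beyond the scatter) from compound 2 to compound 1 and an at least 500-fold higher number (2.69 log units; beyond the scatter) from compound 3 to compound 4; the limit leaves it open whether they differ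

The compounds shown leave open whether the loss would hold on a core carrying an amine or a carboxylic acid, and whether a longer chain on the selenium, such as an ethyl group, would keep the growth inhibition seen with compound 2 and compound 3. They also leave open how far the two sulfur compounds lie beyond the limit they share: the limit of > 100000 nM in this assay, at which 2 of the 4 values shown sit.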